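The source may hold more compounds than are shown below. What is called first, only, known or untested is meant among the compounds shown, and "the series" means these compounds.

Measured set in a functional assay on L1210 cells (Mus musculus) for inhibition, read by MTT assay, with a stated time of 72 h; a higher number here means a weaker inhibitor, a lower number a stronger inhibitor:
- compound 1 `COc1cc(NC(C)CCCNC(=O)Nc2ccc(Br)cc2)c2ncccc2c1`; in this assay compound 1 gives 18000 nM
- compound 2 `COc1cc(NC(C)CCCNC(=O)NNC(=O)Nc2ccc(F)cc2)c2ncccc2c1`; in this assay compound 2 gives 104000 nM
- compound 3 `COc1cc(NC(C)CCCNC(=O)NNC(=O)Nc2ccc(Br)cc2)c2ncccc2c1`; in this assay compound 3 gives 51000 nM

Compound 2 holds the highest number of the three. Its nearest neighbour is compound 3: a 2.0-fold lower number from compound 2 to compound 3 (0.31 log units; beyond the scatter). The largest gap separates it from compound 1: a 5.8-fold higher number from compound 1 to compound 2 (0.76 log units; beyond the scatter).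

Compound 4 `COc1cc(NC(C)CCCNC(=O)Nc2cccc(C(F)(F)F)c2)c2ncccc2c1` is not yet measured. Relative to compound 2 the change is 3-(trifluoromethyl)phenyl in place of ((4-fluorophenyl)carbamoyl)amino on an amide-type nitrogen.

For the measured compounds named here, two measured steps bear on this. Both run the other way: a 5.8-fold higher number from compound 1 to compound 2 (0.76 log units; beyond the scatter) and a 2.8-fold higher number from compound 1 to compound 3 (0.45 log units; beyond the scatter), where the aryl group on the amide-type nitrogen of compound 1 was replaced by a ((4-fluorophenyl)carbamoyl)amino or ((4-bromophenyl)carbamoyl)amino group, and the number rose each time. Compound 4 undoes that kind of extension, so a drop back toward the range of compound 1 is expected. Going by the values given here, no measured pair compares 3-(trifluoromethyl)phenyl with 4-bromophenyl, so the exact landing point is uncertain. The expected step is a 5.2-fold lower number from compound 2 to compound 4 (0.72 log units; beyond the scatter). For compound 4 the estimate is 20000 nM, with a range from 7000 nM to 55000 nM.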

Compound 4, half-maximal inhibitory concentration: 9200 nM
Compound 4: the middle estimate sits 2.2-fold (0.34 log units) above what was measured; the measured number falls inside the stated range.
By their numbers in this assay, from the lowest: compounds 4 and 1 (each within the scatter of the next); then compound 3; then compound 2.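

On the amide-type nitrogen in this assay, 3-(trifluoromethyl)phenyl separates clearly from both carbamoyl-bearing groups, with an 11-fold lower number from compound 2 to compound 4 (1.05 log units; beyond the scatter) as a large step and a 5.5-fold lower number from compound 3 to compound 4 (0.74 log units; beyond the scatter) as a modest one. With the aryl group sitting directly on that nitrogen, the two aryl groups cannot be told apart, as a 2.0-fold lower number from compound 1 to compound 4 (0.29 log units; within the scatter) shows, so this position tolerates the exchange of 4-bromophenyl for 3-(trifluoromethyl)phenyl. Nothing available gives a cause for these steps.

From the compounds shown here alone, it remains open whether a benzyl or cyclohexyl group on this nitrogen would keep the number near that of compound 4. Also open, going by these compounds, is how a 3-(trifluoromethyl)phenyl group would read when carried on the longer carbamoyl-amino extension, which would separate the effect of the aryl group from that of the extension.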